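The source may hold more compounds than are shown below. What is called first, only, known or untested is meant among the compounds shown, and "the series" means these compounds.

The study centres on compound 1 `CS(=O)(=O)CCCn1c(Cn2c(=O)n(C3CC3)c3ccncc32)cc2cc(Cl)ccc21` and a close relative, compound 2 `CS(=O)(=O)CCCn1c(Cn2c(=O)n(C3CN(S(C)(=O)=O)C3)c3ccncc32)cc2cc(Cl)ccc21`. In an ADME assay on HeLa cells (Homo sapiens) for cytotoxicity, read by ATP content, with a stated time of 3 days (a lower number here means that less compound is tolerated, a higher number that more compound is tolerated), compound 1 reaches only a limit of the assay, > 50000 nM. Compound 2 likewise sits at a limit in this assay, giving > 50000 nM. The two differ in a single place, yet the step that the two limits leave unreadable from compound 1 to compound 2 cannot be read because the limit of > 50000 nM in this assay, at which 2 of the 2 values shown sit, is where both values sit. Compound 1 therefore stands at the edge of what this assay can report, with no number of its own.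

Compound 3 `N=C(CCCn1c(Cn2c(=O)n(C3CC3)c3ccncc32)cc2cc(Cl)ccc21)NO` alters compound 1 in another place: a group of 4 heavy atoms (1 carbon, 2 nitrogen, 1 oxygen; no ring) in place of a group of 4 heavy atoms (1 carbon, 2 oxygen, 1 sulfur; no ring), on a saturated chain carbon, three bonds along the chain from an aromatic nitrogen. Within the data shown here, no measured step touches this change, and the one step in hand gives no readable size. Among the measured compounds shown here, the expectation must rest on compound 1 alone, and its limit offers no sign of a step of any size in either direction in this assay. Compound 3 is accordingly expected to land near the same limit, with an estimated 40000 nM, ranging from 10000 nM to 100000 nM. The step this implies, an at least 1.2-fold lower number from compound 1 to compound 3 (0.09 log units; that floor lies within the scatter), is expected to be small.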

Compound 3, half-maximal cytotoxic concentration: > 50000 nM
Compound 3: only a limit was reported (the forecaster's own chance of this, stated with the estimate: 70%); at least 1.2-fold (0.09 log units) between middle value and limit.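

In this assay compound 3 gives > 50000 nM, which is a limit of the assay. The change from compound 1 to compound 3 therefore yields no readable step: the limit of > 50000 nM in this assay, at which 3 of the 3 values shown sit.

The compounds shown leave open at what concentration any of them would reach a half-maximal effect in this assay, and whether the exchanged groups make any difference there.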